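From thiophen-2-yl to phenyl on the shared core

The source may hold more compounds than are shown below. What is called first, only, known or untested is meant among the compounds shown, and "the series" means these compounds.

In a functional assay on HeLa S3 cells (Homo sapiens) for antiproliferative activity, read by XTT assay, with a stated time of 72 h (on this read-out higher numbers stand for weaker inhibition and lower numbers for stronger inhibition), the measured compounds are
Compound 1 `CSc1ncnc2c1c(-c1ccoc1)cn2[C@@H]1O[C@H](CO)[C@@H](O)[C@H]1O` gives 5390 nM
Compound 2 `CSc1ncnc2c1c(-c1cccs1)cn2[C@@H]1O[C@H](CO)[C@@H](O)[C@H]1O` gives 1960 nM

Among the compounds with values here, of these two, compound 2 stands lowest with 1960 nM and thus shows the stronger inhibition in this assay so far. The next compound, compound 3 `CSc1ncnc2c1c(-c1ccccc1)cn2[C@@H]1O[C@H](CO)[C@@H](O)[C@H]1O`, carries phenyl in place of thiophen-2-yl on an aromatic carbon. Within the data shown here, one measured step bears on this change, at the same place on the shared core. Replacing furan-3-yl with thiophen-2-yl gave a 2.8-fold lower number from compound 1 to compound 2 (0.44 log units; beyond the scatter), a modest step beyond the scatter. That step shows that the aromatic group at this place can shift the number, but no phenyl has yet been measured there, so the direction remains uncertain. Among the measured compounds shown here, with compound 2 at 1960 nM as the lower of only two numbers, a modest move toward a higher number is the likelier outcome. The expected change is a 2.0-fold higher number from compound 2 to compound 3 (0.31 log units; beyond the scatter) and is of similar size to the step from furan-3-yl to thiophen-2-yl. For compound 3 the estimated value is 4000 nM, with an expected range of 1300 nM to 12000 nM.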

Compound 3, half-maximal inhibitory concentration: > 20000 nM
Compound 3: no number, only a limit; the forecaster's own chance of this, stated with the estimate: 15%; middle value at least 5.0-fold (0.69 log units) from the limit.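

In this assay compound 3 gives no number, only a limit of > 20000 nM: the limit of > 20000 nM in this assay, at which 1 of the 3 values shown sits. Phenyl in place of thiophen-2-yl gives an at least 10-fold higher number from compound 2 to compound 3 (1.00 log units; beyond the scatter), and phenyl in place of furan-3-yl gives an at least 3.7-fold higher number from compound 1 to compound 3 (0.56 log units; beyond the scatter). Within the data shown here, the earlier step compared only two five-membered aromatic rings, whereas this result shows that on this aromatic carbon a six-membered aromatic ring of carbon only reads well on the weaker side of both, so the change of ring costs more here than the exchange of one five-membered ring for the other.

From the compounds shown here alone, what remains open is which difference between the groups goes with this loss, as phenyl differs from thiophen-2-yl both in ring size and in the lack of a hetero atom, and how far the true value of compound 3 lies beyond its limit. A pyridin-3-yl ring, which is six-membered and carries a ring nitrogen, would bear on that question, and how an amine or a short alkyl chain at this place would read in this assay is also left open.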